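The source may hold more compounds than are shown below. What is called first, only, known or untested is meant among the compounds shown, and "the series" means these compounds.

Compound 1 `O=C(O)c1ccc(COc2cccc(/C=C3\SC(=S)N(c4ccccc4)C3=O)c2)cc1` was tested in an assay on isolated protein for inhibition of Apoptosis regulator Bcl-2 (Homo sapiens), read by fluorescence polarization (on this read-out lower numbers stand for stronger inhibition and higher numbers for weaker inhibition), and gave only a limit, > 10000 nM. It therefore sits at the limit of > 10000 nM in this assay, at which 1 of the 2 values shown sits. Compound 2 `O=C(O)c1ccc([N+](=O)[O-])c(COc2ccc(/C=C3\SC(=S)N(c4ccccc4)C3=O)cc2)c1` gives 9000 nM in this assay, a weak result. Compound 3 `O=C(O)c1ccc(COc2cccc(/C=C3\SC(=S)N(c4ccc([N+](=O)[O-])cc4)C3=O)c2)cc1` has not yet been measured in this assay; it differs from compound 1 by nitro in place of hydrogen on an aromatic carbon. Within the data shown here, no measured pair shows this same change, so the size of the step in this assay cannot be read off from the data, and a shift beyond the usual scatter is not expected. Compound 3 is estimated at 9000 nM, with a range from 3000 nM to 30000 nM. The expected step is an at least 1.1-fold lower number from compound 1 to compound 3 (0.04 log units; that floor lies within the scatter).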

Compound 3, inhibition constant: > 10000 nM
Compound 3 ended at the assay's limit (the forecaster's own chance of this, stated with the estimate: 50%); middle value at least 1.1-fold (0.04 log units) away from the limit.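

Compound 1 and compound 3 both give only a limit, so no step can be read between them: the limit of > 10000 nM in this assay, at which 2 of the 3 values shown sit. Going by these compounds, whether nitro in place of hydrogen changes the result in this assay at all stays open.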